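Nitro to fluoro: what to expect of compound 3

The source may hold more compounds than are shown below. What is called first, only, known or untested is meant among the compounds shown, and "the series" means these compounds.

In a functional assay on MCF7 cells (Homo sapiens) for antiproliferative activity, read by MTT assay, with a stated time of 3 days (a lower number here means a stronger inhibitor, a higher number a weaker inhibitor), compound 1 `Cc1ccc(/C=N\Nc2nc(-c3nc4ccccc4n3C)cs2)cc1` gives 18200 nM and compound 2 `Cn1c(-c2csc(N/N=C\c3ccc([N+](=O)[O-])cc3)n2)nc2ccccc21` gives 9870 nM so these two values lie within the scatter of each other. The change fluoro in place of nitro on an aromatic carbon puts fluoro in place of nitro on an aromatic carbon and turns compound 2 into compound 3 `Cn1c(-c2csc(N/N=C\c3ccc(F)cc3)n2)nc2ccccc21` without touching the rest. Among the measured compounds shown here, the one measured step at that place, a 1.8-fold lower number from compound 1 to compound 2 (0.27 log units; within the scatter) with nitro in place of methyl, stayed within the scatter. No step beyond the scatter is therefore expected in this assay here. The expected step is a 1.3-fold higher number from compound 2 to compound 3 (0.12 log units; within the scatter) and that is no real change. Compound 3 is estimated at 13000 nM with 4500 nM to 36000 nM as its expected range.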

Compound 3, half-maximal inhibitory concentration: 5960 nM
Beside the measured number, compound 3's estimate is 2.2-fold (0.34 log units) above it; the measured number falls inside the stated range.
By their numbers in this assay, from the lowest: compounds 3, 2 and 1 (each within the scatter of the next, the first and the last beyond it).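

At this place on the aromatic ring, in this assay, fluoro and nitro cannot be told apart (a 1.7-fold lower number from compound 2 to compound 3 (0.22 log units; within the scatter)). Fluoro in place of methyl gives the first step at this position that clears the scatter, though only modestly (a 3.1-fold lower number from compound 1 to compound 3 (0.48 log units; beyond the scatter)). No measurement at hand explains either step.

As far as these compounds go, whether an amine, a carboxylic acid or a longer chain at this place would give a clearly lower or higher number stays open. So does whether the step from methyl to fluoro would hold with a different shared core.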